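The compounds below may be only part of what the source reports. "The series", "measured", "known", "first", "only" and "open" are said of these compounds alone.

Among the two compounds measured in an assay on isolated protein for inhibition of Nitric oxide synthase, inducible (Homo sapiens), read by scintillation counting, with a stated time of 30 min, tested at 50 uM (a higher number here means more inhibition at the concentration tested (going by the name of the read-out), a lower number less inhibition), compound 2 `CC1(C)SC(c2cc(Cl)ccc2N)=NN1C(=O)C1CC1` stands lowest, at 23.2%, while compound 1 `CCCC(=O)N1N=C(c2cc(Cl)ccc2N)SC1(C)C` gives 66.2%. Compound 3 `CC1(C)SC(c2cc(Cl)ccc2N)=NN1C(=O)C1CCCCC1` differs from compound 2 by cyclohexyl in place of cyclopropyl on a carbonyl carbon. Within the data shown here, the one measured step that bears on this, a number 43 percentage points lower from compound 1 to compound 2 (beyond the scatter), was large and downward on going from propyl to cyclopropyl, so the move from cyclopropyl to cyclohexyl is expected to run the other way, with a step beyond the scatter. Compound 3 is therefore estimated at 55%, between 25% and 80%, an expected step of a number 31.8 percentage points higher from compound 2 to compound 3 (beyond the scatter).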

Compound 3, a percentage reported as inhibition, at one concentration (the size of the read-out at that concentration, not a potency): 7.61%
Estimate against measurement, compound 3: 47.4 percentage points above, outside the stated range (below it).
By their numbers in this assay, from the lowest: compound 3; then compound 2; then compound 1.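

In this assay a larger ring on the carbonyl carbon does not bring back what the cyclopropyl ring lost, since cyclohexyl in place of cyclopropyl gives a number 15.6 percentage points lower from compound 2 to compound 3 (beyond the scatter) and cyclohexyl in place of propyl gives a number 58.6 percentage points lower from compound 1 to compound 3 (beyond the scatter) in the same series. At this position both rings therefore fall short of the open propyl chain, and the larger ring gives the lowest number of the three. Nothing at hand gives a reason for this result. As far as these compounds go, whether a longer chain such as pentyl, a branched one such as isopropyl, or an amine at this place would match or pass compound 1 remains open.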